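Phenyl swaps on the shared core: compound 3 to compound 4

The source may hold more compounds than are shown below. What is called first, only, known or untested is meant among the compounds shown, and "the series" means these compounds.

Measured so far in a functional assay on KB cells (Homo sapiens) for antiproliferative activity, read by sulforhodamine B assay, with a stated time of 3 days; on this read-out lower numbers stand for an effect already at smaller amounts and higher numbers for an effect only at larger amounts of compound
compound 1 `CCC1=C(O)c2c(oc(-c3ccccc3C)cc2=O)C(CC)(CC)C1=O` gives 40.9 uM
compound 2 `CCC1=C(O)c2c(oc(-c3ccc(C)c(Cl)c3)cc2=O)C(CC)(CC)C1=O` gives 39 uM
compound 3 `CCC1=C(O)c2c(oc(-c3ccc(OC)c(C)c3)cc2=O)C(CC)(CC)C1=O` gives 28.5 uM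

Compound 3 stands at 28.5 uM and is not separated from the other two measured compounds. The measured steps are a 1.4-fold lower number from compound 1 to compound 3 (0.16 log units; within the scatter) and a 1.4-fold lower number from compound 2 to compound 3 (0.14 log units; within the scatter), and both lie within the scatter.

The next entry is compound 4 `CCC1=C(O)c2c(oc(-c3cccc(C)c3C)cc2=O)C(CC)(CC)C1=O`, which differs from compound 3 as follows: 2,3-dimethylphenyl in place of 4-methoxy-3-methylphenyl on an aromatic carbon. The swap sits on an aromatic carbon next to the ring oxygen. Among the compounds with values here, no measured step covers this exact swap. The closest neighbour by group name is compound 1, which carries 2-methylphenyl and lies a 1.4-fold lower number from compound 1 to compound 3 (0.16 log units; within the scatter). The remaining step is a 1.0-fold lower number from compound 1 to compound 2 (0.02 log units; within the scatter), also within the scatter. Across these three compounds, no phenyl swap has moved this assay beyond the scatter, and none goes against this, although three compounds are thin evidence.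

No step beyond the scatter is therefore expected, with the estimate placed between the values of compound 3 and compound 1. The expected change is a 1.2-fold higher number from compound 3 to compound 4 (0.09 log units; within the scatter). For compound 4 the estimated value is 35 uM, with an expected range of 20 uM to 60 uM.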

Compound 4, concentration for half-maximal effect: 3.1 uM
Compound 4: middle estimate off by 11-fold (1.05 log units), on the high side, outside the stated range (below it).
By their numbers in this assay, from the lowest: compound 4; then compounds 3, 2 and 1 (each within the scatter of the next).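

In this assay the phenyl group on the aromatic carbon next to the ring oxygen now proves able to move the number beyond the scatter: 2,3-dimethylphenyl gives a clear step against 4-methoxy-3-methylphenyl (a 9.2-fold lower number from compound 3 to compound 4 (0.96 log units; beyond the scatter)) and against 3-chloro-4-methylphenyl (a 13-fold lower number from compound 2 to compound 4 (1.10 log units; beyond the scatter)). The tightest comparison is with the 2-methylphenyl group (a 13-fold lower number from compound 1 to compound 4 (1.12 log units; beyond the scatter)), where the whole change is methyl in place of hydrogen, so a swap this small is enough and no wholesale change of the phenyl group is needed. Compound 1, compound 2 and compound 3 lie within the scatter of each other, so among the four phenyl groups shown only 2,3-dimethylphenyl stands apart, and neither the 2-methylphenyl of compound 1 nor the 4-methoxy-3-methylphenyl of compound 3 shares its result.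

Still open, on these data alone, is whether the lower number depends on two methyl groups specifically, or would hold with 2,3-dichlorophenyl, 3-ethyl-2-methylphenyl or an amine in place of one methyl. Nothing available so far bears on what lies behind this step.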